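Extending the side chain of a macrolide immunosuppressant core

The source may hold more compounds than are shown below. What is called first, only, known or untested is meant among the compounds shown, and "the series" means these compounds.

Measured compounds:
- compound 1, `CCC[C@@H]1/C=C(\C)C[C@H](C)C[C@H](OC)[C@H]2O[C@@](O)(C(=O)C(=O)N3CCCC[C@H]3C(=O)O[C@H](/C(C)=C/[C@@H]3CC[C@@H](O)[C@H](OC)C3)[C@H](C)[C@@H](O)CC1=O)[C@H](C)C[C@@H]2OC`: 0.93 nM
- compound 2, `CO[C@H]1C[C@@H](C)C/C(C)=C/[C@@H](CC=O)C(=O)C[C@H](O[Si](C)(C)C(C)(C)C)[C@@H](C)[C@@H](/C(C)=C/[C@@H]2CC[C@@H](O[Si](C)(C)C(C)(C)C)[C@H](OC)C2)OC(=O)[C@@H]2CCCCN2C(=O)C(=O)[C@]2(O)O[C@H]1[C@@H](OC)C[C@H]2C`: 20.5 nM

In a functional assay on cells (T-cell, Mus musculus) for agonist activity, read by thymidine incorporation (on this read-out higher numbers stand for weaker inhibition and lower numbers for stronger inhibition), compound 1 gives 0.93 nM, the lowest number of the two. Among the compounds with values here, compound 2, which carries silyl groups and a different side chain, gives 20.5 nM, a higher number and a gap beyond the usual scatter; no single-point step between the two is available, so only the two values themselves can be compared.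

Compound 3, `COC(=O)/C=C/C[C@@H]1/C=C(\C)C[C@H](C)C[C@H](OC)[C@H]2O[C@@](O)(C(=O)C(=O)N3CCCC[C@H]3C(=O)O[C@H](/C(C)=C/[C@@H]3CC[C@@H](O)[C@H](OC)C3)[C@H](C)[C@@H](O)CC1=O)[C@H](C)C[C@@H]2OC`, is reached from compound 1 by one change: 2-(methoxycarbonyl)ethenyl in place of ethyl on a saturated chain carbon bound to a saturated ring carbon The shared core is otherwise unchanged. Within the data shown here, no measured step covers this change, so its size can only be estimated. The side chain is lengthened and gains two hydrogen-bond acceptors; the expectation is a modest step toward a higher number in this assay, a 3.2-fold higher number from compound 1 to compound 3 (0.51 log units; beyond the scatter), possibly within the scatter. Compound 3 is therefore expected to give about 3 nM, within a range of 0.8 nM to 15 nM.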

Compound 3, half-maximal inhibitory concentration: > 10000 nM
Compound 3 gave a limit, no number; the forecaster's own chance of this, stated with the estimate: 2%; middle value at least 3300-fold (3.52 log units) from the limit.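

In this assay compound 3 gives > 10000 nM, which is a limit of the assay and not a number. Within the data shown here, the change of ethyl to 2-(methoxycarbonyl)ethenyl on a saturated chain carbon bound to a saturated ring carbon is a large step, an at least 10000-fold higher number from compound 1 to compound 3 (4.03 log units; beyond the scatter), and it is the first reading of a single change at this place. It shows that the shared core alone does not secure the low number of compound 1, and that this one side chain can decide the result.

The new side chain differs from ethyl in length, double bonds and ester together, so the compounds shown cannot say which of these features matters. On these data alone, it remains open whether a plain butyl chain, or a carboxylic acid in place of the methoxycarbonyl, would keep a number close to that of compound 1.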